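Sulfanyl for benzylamino on the shared core: expected shift

A few compounds are considered here, and "the series" means these few. Any claim that something is new, unique, unknown or untested is made for them only; others in the source may bear on it.

Compound 3 `Nc1cc(N)c2nc(-c3ccccc3)c(NCc3ccc(F)cc3)nc2c1` gives the lowest number of the three measured: in a functional assay on MCF7 cells (Homo sapiens) for inhibition, read by sulforhodamine B assay, with a stated time of 48 h (on this read-out higher numbers stand for weaker inhibition of growth and lower numbers for stronger inhibition of growth), compound 3 gives 3020 nM. Compound 1 `Nc1cc(N)c2nc(-c3ccccc3)c(NCc3ccc(Cl)c(Cl)c3)nc2c1` gives 12300 nM and compound 2 `COc1ccc(CNc2nc3cc(N)cc(N)c3nc2-c2ccccc2)cc1OC` gives 25700 nM; the steps of a 4.1-fold lower number from compound 1 to compound 3 (0.61 log units; beyond the scatter) and an 8.5-fold lower number from compound 2 to compound 3 (0.93 log units; beyond the scatter) both lie beyond the scatter, so compound 3 is the strongest inhibitor here. Compound 4 `Nc1cc(N)c2nc(-c3ccccc3)c(Sc3ccc(Cl)c(Cl)c3)nc2c1` differs from compound 3 by (3,4-dichlorophenyl)sulfanyl in place of (4-fluorobenzyl)amino on an aromatic carbon. For the measured compounds named here, the only step that bears on this is a 4.1-fold lower number from compound 1 to compound 3 (0.61 log units; beyond the scatter), which shows 3,4-dichlorophenyl weaker than 4-fluorophenyl; the exchange of the benzylamino linker for a sulfanyl has no measured counterpart. A higher number is therefore expected, roughly reversing that step: compound 4 is estimated at 12000 nM, with a range of 3000 nM to 50000 nM, an expected step of a 4.0-fold higher number from compound 3 to compound 4 (0.60 log units; beyond the scatter).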

Compound 4, concentration for 50% growth inhibition: 5250 nM
The estimate for compound 4 lay 2.3-fold (0.36 log units) above the measured number, and the stated range covers the measured number.
By their numbers in this assay, from the lowest: compounds 3 and 4 (each within the scatter of the next); then compound 1; then compound 2.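

The exchange of (4-fluorobenzyl)amino for (3,4-dichlorophenyl)sulfanyl on this aromatic carbon gives a 1.7-fold higher number from compound 3 to compound 4 (0.24 log units; within the scatter), so the two groups cannot be told apart here. The 3,4-dichlorophenyl group is carried in compound 1 at 12300 nM and in compound 4 at 5250 nM, so it does not fix a high number once the linker is sulfanyl. No supporting data bear on why this is so.

Linker and aryl group change together in this step, so their separate contributions remain open. A (4-fluorophenyl)sulfanyl group would separate them, and an ether oxygen linker remains a further open case.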